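A Missing Value and an Unmeasured Methoxy Compound

A few compounds are considered here, and "the series" means these few. Any claim that something is new, unique, unknown or untested is made for them only; others in the source may bear on it.

Among the measured compounds shown here, in a functional assay on MCF7 cells (Homo sapiens) for cytotoxicity, read by MTT assay, with a stated time of 72 h (on this read-out higher numbers stand for weaker inhibition and lower numbers for stronger inhibition), compound 1 `N[C@H]1CC[C@H](Nc2c(C(=O)NCc3ccc(F)cc3)nc(Br)c3cccnc23)CC1` gives 2000 nM, the only number in this small set. Compound 2 `COc1ccc(CNC(=O)c2nc(Br)c3cccnc3c2N[C@H]2CC[C@H](N)CC2)cc1` has the entry "not determined" (no result reported). Compound 3 `C[C@H](NC(=O)c1nc(Br)c2cccnc2c1N[C@H]1CC[C@H](N)CC1)c1ccc(F)cc1` has the entry "not determined" (no result reported), so it stands without a single number and offers no direct baseline. Compound 4 `COC(=O)c1nc(Br)c2cccnc2c1N[C@H]1CC[C@H](N)CC1` has not yet been measured. It carries methoxy in place of (1-(4-fluorophenyl)ethyl)amino on a carbonyl carbon. For the measured compounds named here, no measured pair shows the size of such a step in this assay. Measured against compound 1 at 2000 nM, a modest step towards weaker inhibition is expected, though it may not clear the scatter. For compound 4, the estimated value is 5000 nM, with an expected range of 1500 nM to 20000 nM.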

Compound 4, half-maximal inhibitory concentration: > 20000 nM
Compound 4: only a limit was reported; the forecaster's own chance of this, stated with the estimate: 15%; middle value at least 4.0-fold (0.60 log units) from the limit.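

In this assay, among the compounds shown here, putting methoxy in place of (4-fluorobenzyl)amino on a carbonyl carbon gives an at least 10-fold higher number from compound 1 to compound 4 (1.00 log units; beyond the scatter) and so provides the first readable step at this position. It shows that this change weakens inhibition on this read-out by more than the scatter. The value of compound 4 is a limit and not a number: the limit of > 20000 nM in this assay, at which 1 of the 4 values shown sits.

As far as these compounds go, what a methylamino group or a carboxylic acid would give on that carbonyl carbon stays open. With no numbers for compound 2 and compound 3, changes within the amide group also cannot be read.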